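The compounds below may be only part of what the source reports. "The series", "measured", "known", "first", "only" and "open" are said of these compounds alone.

Measured compounds:
compound 1 `COc1cc(-c2nc(SCc3cn(CC(=O)NC(=O)Nc4ccccn4)nn3)nc(Nc3cccc(C(F)(F)F)c3)c2C#N)cc(OC)c1OC`: 8210 nM
compound 2 `COc1cc(-c2nc(SCc3cn(CC(=O)NC(=O)Nc4ccccn4)nn3)nc(Nc3ccc(Cl)cc3)c2C#N)cc(OC)c1OC`: 17500 nM
compound 3 `COc1cc(-c2nc(SCc3cn(CC(=O)NC(=O)Nc4ccccn4)nn3)nc(Nc3cccc(Cl)c3)c2C#N)cc(OC)c1OC`: 15400 nM

In a functional assay on MGC-803 cells (Homo sapiens) for inhibition, read by MTT assay, with a stated time of 72 h (a higher number here means a weaker inhibitor, a lower number a stronger inhibitor), compound 3 sits second highest of the three numbers; its nearest neighbour is compound 2 and the two lie within the scatter of each other, as seen in a 1.1-fold lower number from compound 2 to compound 3 (0.06 log units; within the scatter). Against compound 1 the gap is a 1.9-fold higher number from compound 1 to compound 3 (0.27 log units; within the scatter), also within the scatter. Compound 4 `Cc1ccc(-c2nc(SCc3cn(CC(=O)NC(=O)Nc4ccccn4)nn3)nc(Nc3cccc(Cl)c3)c2C#N)cc1` differs from compound 3 by 4-methylphenyl in place of 3,4,5-trimethoxyphenyl on an aromatic carbon. Within the data shown here, no measured step touches this position; the three measured steps, a 2.1-fold higher number from compound 1 to compound 2 (0.33 log units; beyond the scatter) and a 1.9-fold higher number from compound 1 to compound 3 (0.27 log units; within the scatter) and a 1.1-fold lower number from compound 2 to compound 3 (0.06 log units; within the scatter), all concern the anilino group and are small. No direction can be drawn from them for this change. Compound 4 is therefore estimated near compound 3, at 20000 nM with a wide range from 5000 nM to 80000 nM. The expected step is a 1.3-fold higher number from compound 3 to compound 4 (0.11 log units; within the scatter).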

Compound 4, half-maximal inhibitory concentration: 7890 nM
Compound 4: middle estimate off by 2.5-fold (0.40 log units), on the high side; the range from low to high includes it.
By their numbers in this assay, from the lowest: compounds 4, 1, 3 and 2 (each within the scatter of the next, the first and the last beyond it).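

In this assay, among these compounds, this position is the first one probed outside the anilino group: 4-methylphenyl in place of 3,4,5-trimethoxyphenyl, on the carbon opposite the ring nitrogen, gives a 2.0-fold lower number from compound 3 to compound 4 (0.29 log units; within the scatter). With the 3-chlorophenylamino group held constant, the three methoxy groups are therefore not needed to retain this level of activity. Nothing available bears on the reason for this result.

Still open, from the compounds shown here alone, is whether a plain phenyl, a 4-methoxyphenyl or a phenyl carrying an amine or a carboxylic acid would read differently here. Also open, going by these compounds, is whether the same exchange behaves alike alongside the other anilino groups.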